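Swapping a Sulfate Arm for a Phenyl Ring

A few compounds are considered here, and "the series" means these few. Any claim that something is new, unique, unknown or untested is made for them only; others in the source may bear on it.

Measured so far in an assay on isolated protein for binding affinity to fibroblast growth factor 2 (Homo sapiens), read by surface plasmon resonance; on this read-out higher numbers stand for weaker binding and lower numbers for tighter binding:
compound 1 `CO[C@H]1O[C@H](CNC(=O)CN(CCOS(=O)(=O)O)C(C)=O)[C@@H](OS(=O)(=O)O)[C@H](OS(=O)(=O)O)[C@@H]1OS(=O)(=O)O`, 240000 nM
compound 2 `CCN(CC(=O)NCCO[C@H]1O[C@H](COS(=O)(=O)O)[C@@H](OS(=O)(=O)O)[C@H](OS(=O)(=O)O)[C@@H]1OS(=O)(=O)O)C(=O)CCCCCCCCCOS(=O)(=O)O`, 157000 nM
compound 3 `CCN(CC(=O)NC[C@H]1O[C@H](OC)[C@@H](OS(=O)(=O)O)[C@@H](OS(=O)(=O)O)[C@@H]1OS(=O)(=O)O)C(=O)CCCc1ccccc1`, 400000 nM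

All three compounds share a sulfated sugar core carrying a short amide-linked side chain, and all three bind weakly. Compound 1 stands second highest of the three numbers. Its nearest neighbour is compound 2, whose number is lower, and the furthest is compound 3, whose number is higher; both gaps fall within the scatter of repeated measurements, so the three values cannot be told apart with confidence.

Compound 4 `CO[C@H]1O[C@H](CNC(=O)CN(Cc2ccccc2)C(C)=O)[C@@H](OS(=O)(=O)O)[C@H](OS(=O)(=O)O)[C@@H]1OS(=O)(=O)O` is the next candidate. It keeps the core of compound 1 and changes only the side chain: phenyl in place of (sulfooxy)methyl on a saturated chain carbon bound to an amide-type nitrogen. One arm bearing a sulfate leaves and a plain aromatic ring enters, so the count of sulfate groups falls by one.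

Going by the values given here, the measured values give no step between compounds that differ in one place, so there is no direct precedent for this swap. Given the closeness of compound 1, compound 2 and compound 3, the expected step from compound 1 to compound 4 in this assay is small, estimated as a 1.3-fold higher number from compound 1 to compound 4 (0.10 log units; within the scatter), within the scatter. Compound 4 is expected to give about 300000 nM, in the range 150000 nM to 600000 nM.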

Compound 4, dissociation constant: 192000 nM
The estimate for compound 4 lay 1.6-fold (0.19 log units) above the measured number, within the range that was stated.
By their numbers in this assay, from the lowest: compounds 2, 4, 1 and 3 (each within the scatter of the next, the first and the last beyond it).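

In this assay, going by these compounds alone, putting phenyl in place of (sulfooxy)methyl on a saturated chain carbon bound to an amide-type nitrogen gives a 1.3-fold lower number from compound 1 to compound 4 (0.10 log units; within the scatter) and so offers the first direct comparison at this position. Compound 4 carries one sulfate group fewer than compound 1 and has a plain aromatic ring in that group's place, yet the two compounds cannot be told apart in this measurement, so this single swap shows no detectable loss or gain in binding. Nothing among the data shown accounts for why these two different groups give numbers within the scatter of each other.

The compounds shown leave open whether this place responds to any other group, such as a carboxylic acid, an amine or a longer chain ending in a sulfate, and whether any of these would move the number beyond the scatter. Within the data shown here, it also remains open whether the same swap would read alike on another core, as compound 1 and compound 4 are the only pair here that differ in one place.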